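Trimming the thiophene of compound 1

This account rests on a few compounds, and the source may have more. Where it says the series, first, only, none or still open, it means among the compounds named here.

Measured in a functional assay on cells (Cancer cell lines, Homo sapiens) for inhibition; a lower number here means a stronger inhibitor of growth, a higher number a weaker inhibitor of growth:
- compound 1 `Cc1cc(-c2nc3sc(C)cn3c2/C=N/NC(=N)N)c(C)s1` gives 12000 nM
- compound 2 `Cc1cn2c(/C=N/Nc3ccccn3)c(-c3ccc(Cl)c([N+](=O)[O-])c3)nc2s1` gives 9120 nM
- compound 3 `Cc1cc(-c2nc3sccn3c2/C=N/NC(=N)N)c(C)s1` gives 17400 nM

Compound 1 lies within the scatter of both compound 2 and compound 3, so these numbers set no real order among them. The unmeasured compound 4 `Cc1cn2c(/C=N/NC(=N)N)c(-c3cccs3)nc2s1` keeps the core of compound 1 but carries thiophen-2-yl in place of 2,5-dimethylthiophen-3-yl (thiophen-2-yl in place of 2,5-dimethylthiophen-3-yl on an aromatic carbon). Going by the values given here, only one measured step offers a guide, and only loosely. Hydrogen in place of methyl on an aromatic carbon of the core gave a 1.5-fold higher number from compound 1 to compound 3 (0.16 log units; within the scatter), and this change leaves the thiophene untouched. No step beyond the scatter is therefore expected in this assay, in either direction. The expected step is a 1.2-fold lower number from compound 1 to compound 4 (0.08 log units; within the scatter). For compound 4 the estimate is 10000 nM, with an expected range from 3500 nM to 28000 nM.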

Compound 4, concentration for 50% growth inhibition: 6460 nM
Compound 4: the middle estimate sits 1.5-fold (0.19 log units) above what was measured, within the range that was stated.
By their numbers in this assay, from the lowest: compounds 4, 2, 1 and 3 (each within the scatter of the next, the first and the last beyond it).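

In this assay, thiophen-2-yl in place of 2,5-dimethylthiophen-3-yl gives a 1.9-fold lower number from compound 1 to compound 4 (0.27 log units; within the scatter). Going by these compounds alone, earlier, the only step between measured compounds was a change on the core, so this is the first look at the group on this aromatic carbon. Here, removing both methyl groups and changing how the thiophene is attached does not move the number beyond the scatter.

As far as these compounds go, whether an amine or a carboxylic acid on this thiophene would produce a real change remains open. No measurement shown gives a reason for this step.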